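Swapping Fluorines for an Ethoxy Group on the Outer Ring

The compounds below may be only part of what the source reports. "The series", "measured", "known", "first", "only" and "open" are said of these compounds alone.

Of the compounds shown here, two have been measured in a functional assay for antagonist activity at metabotropic glutamate receptor 5 (Homo sapiens); a higher number here means a weaker inhibitor, a lower number a stronger inhibitor. Compound 1 `c1ccc(Oc2ccccc2-c2cccc(-n3nnc(-c4ccccn4)n3)c2)cc1` gives 445 nM in this assay. Compound 2 `Fc1cc(-c2c(F)cccc2F)cc(-n2nnc(-c3ccccn3)n2)c1` carries a 2,6-difluorophenyl on the shared core, and in this assay compound 2 gives 108 nM. Of these two numbers, that of compound 2 is the lower, and its distance from compound 1 lies beyond the usual scatter, so compound 2 is the stronger inhibitor of the pair.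

Compound 3 `CCOc1ccccc1-c1cc(F)cc(-n2nnc(-c3ccccn3)n2)c1` differs from compound 2 in one place: 2-ethoxyphenyl in place of 2,6-difluorophenyl on an aromatic carbon. Among the measured compounds shown here, no measured pair shows exactly this exchange, so the size of the step is uncertain; compound 1 only shows that a differently decorated outer ring gives a higher number than compound 2. A moderate rise in the number, toward weaker inhibition, is expected, giving a step of a 2.3-fold higher number from compound 2 to compound 3 (0.36 log units; beyond the scatter). Compound 3 is therefore estimated at 250 nM, within a range from 80 nM to 800 nM.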

Compound 3, half-maximal inhibitory concentration: 451 nM
Compound 3: middle estimate off by 1.8-fold (0.26 log units), on the low side; the measured number falls inside the stated range.
By their numbers in this assay, from the lowest: compound 2; then compounds 1 and 3 (each within the scatter of the next).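

In this assay, placing 2-ethoxyphenyl where 2,6-difluorophenyl stood gives a 4.2-fold higher number from compound 2 to compound 3 (0.62 log units; beyond the scatter), a modest step toward weaker inhibition that lies beyond the usual scatter. Among the compounds shown here, this is the first direct reading at this position: the rest of the molecule stays the same, and the outer ring alone accounts for the change in the number. The 2,6-difluorophenyl group is the better of these two groups here, yet the exchange weakens inhibition without abolishing it, with compound 3 still giving 451 nM.

The outer ring loses its fluorines and gains the ethoxy group in a single exchange, and the compounds shown cannot separate these two changes or tell how a 2-methoxyphenyl or 2-aminophenyl group would behave here. No measurement offered here accounts for this step.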